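Pyrimidine for pyridine on the tetrazole of compound 3

A few compounds are considered here, and "the series" means these few. Any claim that something is new, unique, unknown or untested is made for them only; others in the source may bear on it.

Measured in an assay on Sf9 cells for inhibition of protein deacetylase HDAC6 (Homo sapiens), read by fluorescence; a higher number here means a weaker inhibitor, a lower number a stronger inhibitor:
- compound 1 `O=C(NO)c1ccc(Cn2nnc(-c3cccc(S(F)(F)(F)(F)F)c3)n2)cc1`: 26 nM
- compound 2 `Cn1c(Sc2c(F)cc(C(=O)NO)cc2F)nnc1-c1ncccc1F`: 6 nM
- compound 3 `O=C(NO)c1ccc(Cn2nnc(-c3ccccn3)n2)cc1`: 9 nM

All three compounds share a hydroxamic acid head and a nitrogen-rich five-membered ring carrying a six-membered aromatic group. Compound 3 gives the second highest of the three numbers in this assay. Its nearest neighbour is compound 2, whose number sits within the usual scatter of compound 3's, so the two cannot be told apart. Compound 1 stands furthest away, with a number beyond the scatter above that of compound 3.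

Compound 4 `O=C(NO)c1ccc(Cn2nnc(-c3ncccn3)n2)cc1` has not yet been measured. It differs from compound 3 in one place: pyrimidin-2-yl in place of pyridin-2-yl on an aromatic carbon

For the measured compounds named here, no measured pair shows the effect of this exchange. The change keeps the size of the group and adds one ring nitrogen. The step from compound 3 to compound 4 in this assay is expected to be small, likely toward a slightly weaker inhibitor, as a 1.7-fold higher number from compound 3 to compound 4 (0.22 log units; within the scatter), and may not exceed the scatter. Compound 4 is therefore estimated at 15 nM, with a range from 5 nM to 45 nM.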

Compound 4, half-maximal inhibitory concentration: 7 nM
Compound 4: the middle estimate sits 2.1-fold (0.33 log units) above what was measured, within the range that was stated.
By their numbers in this assay, from the lowest: compounds 2, 4 and 3 (each within the scatter of the next); then compound 1.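

For the compounds shown here, this is the first pair of compounds that differ only at this position, and in this assay it gives a 1.3-fold lower number from compound 3 to compound 4 (0.11 log units; within the scatter) for the exchange. Adding a second ring nitrogen to the six-membered aromatic ring, on an aromatic carbon of the five-membered aromatic ring with 4 nitrogen, therefore leaves no change that this assay can distinguish from repeat-to-repeat scatter. No supporting data are available that bear on this result.

Only this one exchange is shown at this position, so it remains open how a plain phenyl ring without any ring nitrogen, a carboxylic acid or an amine would compare with compound 3 on the same carbon. As far as these compounds go, whether compound 3 and compound 4 also match against other protein deacetylases remains open too.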